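Thiophene in Place of Furan on a Spiro Scaffold

The source may hold more compounds than are shown below. What is called first, only, known or untested is meant among the compounds shown, and "the series" means these compounds.

Compound 1, `CN1C(=O)[C@@]2(c3ccccc31)N(C)C[C@@H](c1ccco1)[C@@]21Cc2ccccc2C1=O`, was tested in a functional assay on the whole organism (strain Wister albino) for inhibition, with Rattus norvegicus as the target, read by paw edema, with stated times of 1 h and 2 h, at a dose of 50 mg/kg by the intraperitoneal route (a lower number here means less inhibition, a higher number more inhibition at the dose given (going by the name of the read-out)), where compound 1 gives 33.1%. The other measured compound, compound 2, `CN1C[C@@H](c2ccc(Cl)cc2)[C@@]2(Cc3ccccc3C2=O)[C@@]12C(=O)Nc1ccccc12`, shares the same core but has a different ring on the saturated ring carbon and a different amide; in this assay compound 2 gives 28.4%. The two numbers lie within the usual scatter of each other, so compound 1 cannot be set apart from compound 2 on these data.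

Compound 3, `CN1C(=O)[C@@]2(c3ccccc31)N(C)C[C@@H](c1cccs1)[C@@]21Cc2ccccc2C1=O`, has not been measured. It differs from compound 1 by one change: thiophen-2-yl in place of furan-2-yl on a saturated ring carbon. Going by the values given here, no step between two measured compounds exists for a change of this kind, so the expectation rests on the near match of the two measured values alone. The step from compound 1 to compound 3 is expected to be small, a number 0.1 percentage points lower from compound 1 to compound 3 (within the scatter), with no direction beyond the scatter. Compound 3 is therefore estimated at 33%, within a range from 22% to 44%.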

Compound 3, a percentage reported as inhibition, in the whole organism at one dose (the size of the read-out at that dose, not a potency): 10.8%
Estimate against measurement, compound 3: 22.2 percentage points above; the measured number lies below the stated range.
By their numbers in this assay, from the lowest: compound 3; then compounds 2 and 1 (each within the scatter of the next).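

This position is sensitive to a single atom within the ring it carries: in this assay, thiophen-2-yl in place of furan-2-yl gives a number 22.3 percentage points lower from compound 1 to compound 3 (beyond the scatter). The two groups have the same heavy atom count, ring size and hydrogen-bond counts, and differ in those computed terms only in having sulfur rather than oxygen as the hetero atom, so similar counts do not guarantee a similar read-out here. No measurement of any property of the two rings is available to explain the step.

From the compounds shown here alone, it remains open whether a six-membered ring such as pyridin-2-yl, or a furan-2-yl ring carrying an added methyl group or carboxylic acid, would stay close to compound 1 or fall toward compound 3. A single step on one core also cannot show whether this exchange would have a similar effect on a different core.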